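A few compounds are considered here, and "the series" means these few. Any claim that something is new, unique, unknown or untested is made for them only; others in the source may bear on it.

Measured so far:
Compound 1 `O=C(O)COc1cc(Cl)c(C(=O)Nc2cccc(-c3nc4ccccc4s3)c2)cc1[N+](=O)[O-]`: in an ADME assay on HEK293 cells (Homo sapiens) for cytotoxicity, with a stated time of 72 h (a lower number here means that less compound is needed, a higher number that more compound is needed for the effect), compound 1 gives > 25000 nM, which is a limit of the assay.
Compound 2 `Cc1ccc(-c2nc3ccccc3s2)cc1NC(=O)c1cc([N+](=O)[O-])c(N2CCC(C(=O)O)CC2)cc1Cl`: in this assay compound 2 gives > 25000 nM, again a limit of the assay.

For the measured compounds named here, compound 2 thus stands at the limit, with no number of its own; the one further value shown is a limit as well, and what the series offers here is summed up by the limit of > 25000 nM in this assay, at which 2 of the 2 values shown sit. Compound 3 `Cc1ccc(-c2nc3ccccc3s2)cc1NC(=O)c1cc([N+](=O)[O-])c(N2CCCCC2)cc1Cl` is the next to be measured. The change from compound 2 to compound 3 is hydrogen in place of carboxy on a saturated ring carbon. No step between measured compounds exists in this series, so the size of this step has no anchor in shown differences. In this assay the step is expected to be none beyond the scatter, most likely with compound 3 again reported as a limit. The estimate for compound 3 is 25000 nM, with a range from 8000 nM to 60000 nM. The expected step of a number no higher from compound 2 to compound 3 (the limit leaves the size open) is small.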

Compound 3, half-maximal effective concentration: > 25000 nM
Compound 3 gave a limit, no number; the forecaster's own chance of this, stated with the estimate: 65%; the middle value lies on the limit itself.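

For the compounds shown here, compound 2 and compound 3 both stand as limits in this assay, and no step between them can be read. The compounds shown leave open whether the change from 4-carboxypiperidin-1-yl to piperidin-1-yl alters the read-out at all, and where any of them would give a number: the limit of > 25000 nM in this assay, at which 3 of the 3 values shown sit.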